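Swapping the Ring on the Sulfonamide Nitrogen

A few compounds are considered here, and "the series" means these few. Any claim that something is new, unique, unknown or untested is made for them only; others in the source may bear on it.

Measured so far:
compound 1 `Cc1ccc2oc(=O)c(/C=N/c3ccc(S(=O)(=O)NC(=N)N)cc3)c(Cl)c2c1`: 67 nM
compound 2 `Cc1ccc2oc(=O)c(/C=N/c3ccc(S(=O)(=O)Nc4cc(C)on4)cc3)c(Cl)c2c1`: 16 nM

Both compounds share one core and differ only in the group on a sulfonamide nitrogen. In a functional assay on MCF7 cells (Homo sapiens) for cytotoxicity, read by CCK-8 assay, with a stated time of 48 h (a higher number here means a weaker inhibitor, a lower number a stronger inhibitor), compound 1 gives 67 nM, and compound 2 gives 16 nM. Of the two numbers, the lower stands with compound 2; the step between them, a 4.2-fold lower number from compound 1 to compound 2 (0.62 log units; beyond the scatter), lies beyond the scatter, so compound 2 is the stronger of the pair.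

Compound 3 `Cc1ccc2oc(=O)c(/C=N/c3ccc(S(=O)(=O)Nc4nccc(C)n4)cc3)c(Cl)c2c1` carries the change (4-methylpyrimidin-2-yl in place of 5-methyl-1,2-oxazol-3-yl on a sulfonamide nitrogen). Among the measured compounds shown here, no measured step compares these two rings directly. For the measured compounds named here, the only step in hand replaces a group with no ring by a five-membered aromatic ring, and it says nothing about exchanging one aromatic ring for another. With nothing pointing either way, a step within the scatter is expected, a 1.3-fold higher number from compound 2 to compound 3 (0.10 log units; within the scatter). Compound 3 is therefore estimated to give 20 nM in this assay, with a range from 7 nM to 60 nM.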

Compound 3, half-maximal inhibitory concentration: 61 nM
Estimate against measurement, compound 3: 3.1-fold (0.48 log units) below; the whole stated range lies below it.
By their numbers in this assay, from the lowest: compound 2; then compounds 3 and 1 (each within the scatter of the next).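

On this sulfonamide nitrogen, one aromatic ring cannot be assumed to stand in for another: in this assay, putting 4-methylpyrimidin-2-yl in place of 5-methyl-1,2-oxazol-3-yl gives a 3.8-fold higher number from compound 2 to compound 3 (0.58 log units; beyond the scatter). Having a ring here does not by itself set the number either, since the step from the group with no ring to the 4-methylpyrimidin-2-yl ring is a 1.1-fold lower number from compound 1 to compound 3 (0.04 log units; within the scatter), so those two groups cannot be told apart in this assay, and among these three only 5-methyl-1,2-oxazol-3-yl stands apart. Nothing measured here gives a reason for the gap between the two rings.

The two rings differ in ring size and in ring atoms at once, so the change cannot be pinned on either one. Also open, as far as these compounds go, is how a plain phenyl or a pyridin-2-yl group on this sulfonamide nitrogen would compare.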